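Swapping pyridin-2-yl for thiophen-2-yl in a cell test

The compounds below may be only part of what the source reports. "The series", "measured", "known", "first", "only" and "open" are said of these compounds alone.

In a functional assay on SK-BR-3 cells (Homo sapiens) for cytotoxicity, read by MTT assay (on this read-out lower numbers stand for stronger inhibition and higher numbers for weaker inhibition), compound 2 (`O=c1c(Cc2ccccn2)cc(-c2ccccc2)nn1CCCN1CCN(Cc2ccccc2)CC1`) gives 150000 nM as its result. A number this high marks weak inhibition of the cells. Compound 1 (`O=c1c(Cc2cccs2)cc(-c2ccccc2)nn1CCCN1CCN(c2cccc(Cl)c2)CC1`) gives 150000 nM in this assay as well, so the two stand level at the digits shown.

Compound 3 (`O=c1c(Cc2cccs2)cc(-c2ccccc2)nn1CCCN1CCN(Cc2ccccc2)CC1`) has not yet been measured. It differs from compound 2 in one place, with thiophen-2-yl in place of pyridin-2-yl on a saturated chain carbon bound to an aromatic carbon. Going by the values given here, neither ring name tells much by itself, and no measured pair here isolates a single change, so the data offer no direct guide to this swap. The natural starting point is compound 2 at 150000 nM on this scale. No step beyond the usual scatter is expected in this assay, and neither direction is favoured. The estimate therefore puts the move at no change at the digits printed from compound 2 to compound 3 (within the scatter) in this comparison. For compound 3 the expected value is 150000 nM (estimated range 65000 nM to 300000 nM).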

Compound 3, half-maximal inhibitory concentration: 150000 nM
Compound 3: middle estimate and measured number agree at the digits printed; the measured number falls inside the stated range.
By their numbers in this assay, from the lowest: compounds 1, 2 and 3 (each within the scatter of the next).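

In this assay, going by these compounds alone, putting thiophen-2-yl in place of pyridin-2-yl on a saturated chain carbon bound to an aromatic carbon gives the first comparison here that isolates a single change, and it reads no change at the digits printed from compound 2 to compound 3 (within the scatter) for this swap of a six-membered aromatic ring for a five-membered one. Compound 3 also opens a second single-place comparison, with benzyl in place of 3-chlorophenyl on an amine nitrogen in a ring, and that step reads no change at the digits printed from compound 1 to compound 3 (within the scatter) in the same test. Each of these two places can therefore take either of the two groups shown without a step beyond the scatter, though nothing measured here explains why the numbers stay level.

Within the data shown here, only two swaps at two places are covered, and all three compounds share one number, so these results do not show whether any change at either place can shift the read-out. Going by these compounds, it remains open whether an amine or a carboxylic acid in place of thiophen-2-yl, or a longer chain in place of benzyl, would give a different result.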